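Phenyl for Cyclopentyl on the Ring Nitrogen

The source may hold more compounds than are shown below. What is called first, only, known or untested is meant among the compounds shown, and "the series" means these compounds.

Two measured compounds share one core and differ only in the group on an aromatic nitrogen. Going by the values given here, compound 2 `Cc1cc(NC(=O)Cn2nnc(-c3ccccc3)n2)n(C2CCCC2)n1` carries a cyclopentyl there, and in an assay on HEK293 cells for activation of Kir3.1/Kir3.2 (Homo sapiens), read by thallium flux (a lower number here means a smaller maximal response, a higher number a larger maximal response), compound 2 gives 105%, the only plain number in this set. Compound 1 `CCC(C)n1nc(C)cc1NC(=O)Cn1nnc(-c2ccccc2)n1` carries a sec-butyl instead. For compound 1 this assay reports only a limit, > 69%. The step that the limit leaves unreadable from compound 1 to compound 2 therefore has no readable size (the limit of > 69% in this assay, at which 1 of the 2 values shown sits). Compound 3 `Cc1cc(NC(=O)Cn2nnc(-c3ccccc3)n2)n(-c2ccccc2)n1` is the next change: phenyl in place of cyclopentyl on an aromatic nitrogen. Among the compounds with values here, no measured step bears on this change with a known size, since the single step available ends at a limit. The expectation for compound 3 rests on compound 2 alone, with a wide range. Compound 3 is expected to give 95% in this assay, between 65% and 120%. That estimate means an expected step of a number 10 percentage points lower from compound 2 to compound 3 (within the scatter), within the usual scatter.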

Compound 3, largest response reached (Emax), in percent of the reference or control that the assay uses: 66%
Compound 3: the middle estimate sits 29 percentage points above what was measured; the range from low to high includes it.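

Going by these compounds alone, this is the only step at this position with a readable size: in this assay, phenyl in place of cyclopentyl on an aromatic nitrogen gives a number 39 percentage points lower from compound 2 to compound 3 (beyond the scatter), so in this pair the group held there matters for the maximal response. The value of compound 1 is a limit, > 69%. Phenyl in place of sec-butyl gives a number at least 3 percentage points lower from compound 1 to compound 3 (that floor lies within the scatter), which fixes only a floor, so the true size of that step stays unknown: the limit of > 69% in this assay, at which 1 of the 3 values shown sits.

As far as these compounds go, what stays open is whether the lower response goes with an aromatic ring on this nitrogen in general or with phenyl in particular. A cyclohexyl or a benzyl group at the same place would help to separate those two readings.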